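The compounds below may be only part of what the source reports. "The series", "measured", "known", "first", "only" and "open" are said of these compounds alone.

Compound 1 `O=C1/C(=C/c2ccccc2F)CN(Cc2cn(Cc3ccc(F)cc3)nn2)C/C1=C\c1ccccc1F` gives 8700 nM in a functional assay on DU-145 cells (Homo sapiens) for cytotoxicity, read by MTT assay, with a stated time of 24 h (on this read-out lower numbers stand for stronger inhibition and higher numbers for weaker inhibition), the lowest of the two numbers shown for this series. Compound 3 `COc1ccc(/C=C2\CN(C(=S)SCc3cn(Cc4ccc(F)cc4)nn3)C/C(=C\c3ccc(OC)cc3)C2=O)cc1` gives 74600 nM in this assay, a higher number that lies beyond the scatter. Compound 2 `Cc1ccc(/C=C2\CN(C(=S)SCc3cn(Cc4ccccc4Cl)nn3)C/C(=C\c3ccc(C)cc3)C2=O)cc1` returns only a limit of this assay, > 80000 nM, that is the limit of > 80000 nM in this assay, at which 1 of the 3 values shown sits. Compound 4 `O=C1/C(=C/c2ccccc2F)CN(Cc2cn(Cc3cccc(Cl)c3)nn2)C/C1=C\c1ccccc1F` differs from compound 1 by 3-chlorophenyl in place of 4-fluorophenyl on a saturated chain carbon bound to an aromatic nitrogen. No measured pair shares this change, and compounds 2 and 3 carry a different core, so nothing shown sets the size of the step. The expected step from compound 1 to compound 4 is a 1.0-fold higher number from compound 1 to compound 4 (0.01 log units; within the scatter), within the scatter and in no clear direction. Compound 4 is estimated at 9000 nM in this assay, with a range of 3500 nM to 25000 nM.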

Compound 4, half-maximal inhibitory concentration: 4300 nM
Compound 4: the middle estimate sits 2.1-fold (0.32 log units) above what was measured, and the stated range covers the measured number.
By their numbers in this assay, from the lowest: compound 4; then compound 1; then compound 3. At a limit, above all of these: compound 2.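

Compound 1 alone could not show whether the aryl group on a saturated chain carbon bound to an aromatic nitrogen affects the number. In this assay, 3-chlorophenyl in place of 4-fluorophenyl gives a 2.0-fold lower number from compound 1 to compound 4 (0.31 log units; beyond the scatter), so this position responds to the change, though the step is modest. Nothing measured here explains the step.

The halogen and its place on the ring change together, and 3-fluorophenyl or 4-chlorophenyl would be needed to separate the two. Going by these compounds, whether the step carries over to the different core of compounds 2 and 3 also stays open.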